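Swapping the Oxazole for a Methylimidazole: Expected Half-Life

This account rests on a few compounds, and the source may have more. Where it says the series, first, only, none or still open, it means among the compounds named here.

Measured compounds:
compound 1 `CC(C)C(c1ncco1)c1ccc(-c2ccc3cccc(F)c3c2)[nH]c1=O` — 0.178 h
compound 2 `CC(C)C(c1ccc(-c2ccc3cccc(F)c3c2)[nH]c1=O)N1CCN/C1=N\C#N` — 0.632 h
compound 3 `CC(C)C(c1noc(=O)[nH]1)c1ccc(-c2ccc3cccc(F)c3c2)[nH]c1=O` — > 3 h

In an ADME assay on microsomes from liver (Homo sapiens) for metabolic stability (on this read-out higher numbers stand for a longer-lived compound and lower numbers for a shorter-lived compound), compound 1 gives the lowest of the numbers reported so far. For compound 3 the reported value is a limit of this assay, (the limit of > 3 h in this assay, at which 1 of the 3 values shown sits). Compound 4 `Cc1c[nH]c(C(c2ccc(-c3ccc4cccc(F)c4c3)[nH]c2=O)C(C)C)n1` differs from compound 1 by one change: 4-methyl-1H-imidazol-2-yl in place of 1,3-oxazol-2-yl on a saturated chain carbon bound to an aromatic carbon and a saturated chain carbon. Both earlier steps at this same carbon lengthened the half-life: a 3.6-fold higher number from compound 1 to compound 2 (0.55 log units; beyond the scatter) and an at least 16-fold higher number from compound 1 to compound 3 (1.22 log units; beyond the scatter). Neither ring entering there matched the 4-methyl-1H-imidazol-2-yl group, so compound 4 is expected to sit between them, a 2.5-fold higher number from compound 1 to compound 4 (0.40 log units; beyond the scatter). Compound 4 is therefore estimated at 0.45 h, with a likely range from 0.15 h to 1.5 h.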

Compound 4, half-life: 0.09 h
Beside the measured number, compound 4's estimate is 5.0-fold (0.70 log units) above it; the measured number lies below the stated range.
By their numbers in this assay, from the lowest: compounds 4 and 1 (each within the scatter of the next); then compound 2. At a limit, above all of these: compound 3.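

In this assay, 4-methyl-1H-imidazol-2-yl in place of 1,3-oxazol-2-yl gives no readable change: a 2.0-fold lower number from compound 1 to compound 4 (0.30 log units; within the scatter). A longer half-life therefore does not follow from any new ring on this saturated chain carbon, as the other two steps show: a 7.0-fold lower number from compound 2 to compound 4 (0.85 log units; beyond the scatter), and an at least 33-fold lower number from compound 3 to compound 4 (1.52 log units; beyond the scatter). Compound 3 carries a limit of the assay, not a number: the limit of > 3 h in this assay, at which 1 of the 4 values shown sits.

Open, going by these compounds, is whether the methyl group or the imidazole ring itself sets this result. A plain 1H-imidazol-2-yl group at this carbon would separate the two.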